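This account rests on a few compounds, and the source may have more. Where it says the series, first, only, none or still open, it means among the compounds named here.

Three compounds sharing one core have been examined in an ADME assay on CCRF-HSB-2 cells (Homo sapiens) for cytotoxicity, with a stated time of 7 days; on this read-out higher numbers stand for lower toxicity in this test and lower numbers for higher toxicity in this test. Compound 1 `CCCOc1nc(N)nc2c1ncn2/C=C1/CC1(CO)CO` carries a propoxy group on an aromatic carbon, and in this assay compound 1 gives only a limit, > 20000 nM. Compound 2 `Nc1nc(NCc2ccccc2)c2ncn(/C=C3/CC3(CO)CO)c2n1` has benzylamino in place of propoxy on an aromatic carbon, and in this assay compound 2 likewise reaches only a limit, > 20000 nM. Compound 3 `CCCSc1nc(N)nc2c1ncn2/C=C1/CC1(CO)CO`, with propylsulfanyl in place of propoxy on an aromatic carbon, is the only one of the three that returns a number: in this assay compound 3 gives 98000 nM. The steps a step that the two limits leave unreadable from compound 1 to compound 2, a step that the limit leaves unreadable from compound 1 to compound 3 and a step that the limit leaves unreadable from compound 2 to compound 3 cannot be sized because the limit of > 20000 nM in this assay, at which 2 of the 3 values shown sit, hides where two of the values truly lie. Compound 4 `CCCCCCSc1nc(N)nc2c1ncn2/C=C1/CC1(CO)CO` differs from compound 3 by propyl in place of hydrogen on a saturated chain carbon, three bonds along the chain from a sulfur. For the measured compounds named here, none of the measured steps concerns this part of the molecule, and none has a readable size, so no direction can be drawn from them. The writer therefore expects a step of a 1.4-fold lower number from compound 3 to compound 4 (0.15 log units; within the scatter) in this assay that stays within the usual scatter. For compound 4 the estimate in this assay is 70000 nM, with a range from 20000 nM to 200000 nM.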

Compound 4, half-maximal cytotoxic concentration: 60000 nM
Beside the measured number, compound 4's estimate is 1.2-fold (0.07 log units) above it; low and high end bracket the measured number.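

In this assay the series now has its first step that can be sized: a 1.6-fold lower number from compound 3 to compound 4 (0.21 log units; within the scatter). On the saturated chain carbon, three bonds along the chain from a sulfur, propyl in place of hydrogen therefore leaves compound 3 and compound 4 indistinguishable in this read-out, so the propyl-to-hexyl difference on the sulfur gives no measurable effect here, and this holds for this one pair only. The steps that link compound 1 and compound 2 to compound 4 cannot be read, because each of them ends at an assay limit: the limit of > 20000 nM in this assay, at which 2 of the 4 values shown sit.

The compounds shown leave open whether the same holds for a chain longer than hexyl, such as decyl, for a shorter one, such as methyl, or for a chain that ends in an amine or a carboxylic acid. From the compounds shown here alone, it also remains open where compound 1 and compound 2 truly lie relative to the two sulfur-bearing compounds, so nothing can yet be said about how the atom that links the side chain to the shared core bears on this read-out.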